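The source may report more compounds than this note shows. Statements on the series, on what has been measured and on what is new or still open speak of the compounds shown alone.

In a functional assay (aorta) with Rattus norvegicus as the target (on this read-out lower numbers stand for an effect already at smaller amounts and higher numbers for an effect only at larger amounts of compound), compound 2 `COc1ccc(-c2nc(/N=C(\N)[N+]3(C)CCCCC3)sc2-c2ccc(OC)cc2)cc1` gives 21 uM, the higher of the two plain numbers available. The nearest is compound 1 `COc1ccc(-c2nc(/N=C(\N)NC(C)C)sc2-c2ccc(OC)cc2)cc1`, which gives 9.1 uM, and the step of a 2.3-fold higher number from compound 1 to compound 2 (0.36 log units; beyond the scatter) shows how far apart they lie. Compound 3 `COc1ccc(-c2nc(C(=O)N=C(N)N)sc2-c2ccc(OC)cc2)cc1` reaches only an assay limit, > 100 uM, rather than a number (the limit of > 100 uM in this assay, at which 1 of the 3 values shown sits). Compound 4 `COc1ccc(-c2nc(C(=O)N3CCOCC3)sc2-c2ccc(OC)cc2)cc1` has not yet been measured. It differs from compound 2 by a group of 8 heavy atoms (5 carbon, 1 nitrogen, 2 oxygen; one six-membered non-aromatic ring with 2 hetero atoms) in place of a group of 10 heavy atoms (7 carbon, 3 nitrogen; one six-membered non-aromatic ring with 1 hetero atom), on an aromatic carbon.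

Among the compounds with values here, two measured steps bear on this change, as both exchange the guanidine-type group on that aromatic carbon for one attached through a carbonyl: an at least 4.7-fold higher number from compound 2 to compound 3 (0.67 log units; beyond the scatter) and an at least 10-fold higher number from compound 1 to compound 3 (1.04 log units; beyond the scatter). In both cases the number moved to the limit. Compound 4 goes in the same direction, keeping no hydrogen-bond donor and no net charge at that position. The expected step is therefore a 7.1-fold higher number from compound 2 to compound 4 (0.85 log units; beyond the scatter), an increase well beyond the scatter, most likely ending at the limit again. The estimate for compound 4 is 150 uM, with a range from 40 uM to 600 uM.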

Compound 4, concentration for half-maximal effect: < 100 uM
Compound 4 was reported as a limit (the forecaster's own chance of this, stated with the estimate: 70%); middle value at least 1.5-fold (0.17 log units) away from the limit.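

In this assay compound 4 is reported as < 100 uM, which is a limit of the assay and not a number. Compound 3, also attached through a carbonyl, stands at a limit that points the other way, > 100 uM. Within the data shown here, the one step that can be read is a number no higher from compound 3 to compound 4 (the limit leaves the size open), so on this aromatic carbon, a carbonyl link does not by itself put a compound on the upper side of that limit, and (morpholin-4-yl)carbonyl does this with no net charge and 0 hydrogen-bond donors. The steps from compound 1 and compound 2 to compound 4 cannot be read, so the order of these three compounds stays unknown, and the limit itself is one value among those shown: the limit of < 100 uM in this assay, at which 1 of the 4 values shown sits.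

Still open, from the compounds shown here alone, is how far on the lower side of that limit compound 4 truly lies, and whether the oxygen of the morpholine ring matters at all. A (piperidin-1-yl)carbonyl group, or an amide carrying a short open chain, on the same aromatic carbon would separate the ring oxygen and the ring itself from the carbonyl link.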